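Fluoro in place of hydrogen on the propylsulfonyl series

The compounds below may be only part of what the source reports. "The series", "measured", "known", "first", "only" and "open" are said of these compounds alone.

Compound 1 `CCCS(=O)(=O)c1cccc(C#Cc2cc(Cl)ccc2OCC(=O)O)c1` gives < 10 mL.min-1.g-1 in an in vitro ADME assay on microsomes from liver (Rattus norvegicus) for metabolic stability, read by LC-MS, tested at 1 uM (on this read-out lower numbers stand for slow clearance and higher numbers for fast clearance), and this value is a limit of the assay, not a number. Compound 2 `O=C(O)COc1ccc(Cl)cc1C#Cc1ccc(CO)cc1F` gives < 10 mL.min-1.g-1, which is also a limit. Compound 1 therefore sits at the limit of < 10 mL.min-1.g-1 in this assay, at which 2 of the 3 values shown sit. Among the measured compounds shown here, compound 3 `COCCN(C)S(=O)(=O)c1ccc(C)c(C#Cc2cc(Cl)ccc2OCC(=O)O)c1` gives 49 mL.min-1.g-1, the only value in the set that is an actual number.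

Compound 4 `CCCS(=O)(=O)c1ccc(F)c(C#Cc2cc(Cl)ccc2OCC(=O)O)c1` follows from compound 1 by fluoro in place of hydrogen on an aromatic carbon. The new fluoro stands on an aromatic carbon, ortho to a large group and para to a propylsulfonyl group.

For the measured compounds named here, no two measured compounds differ in one place only, so the effect of this change in this assay has no direct measure. The expectation therefore starts from compound 1 and its limit of < 10 mL.min-1.g-1. Only a small rise in clearance is expected, with no shift clearly beyond the usual scatter, and the expected size is a number no lower from compound 1 to compound 4 (the limit leaves the size open). Compound 4 may well read out at the same limit rather than as a number. The estimate for compound 4 is 10 mL.min-1.g-1, with an expected range from 5 mL.min-1.g-1 to 25 mL.min-1.g-1.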

Compound 4, intrinsic clearance in microsomes: < 10 mL.min-1.g-1
Compound 4: only a limit was reported; the forecaster's own chance of this, stated with the estimate: 55%; the middle value sits exactly at the limit.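

Compound 1 and compound 4 both read out as limits and not as numbers in this assay, so no step can be read between them: the limit of < 10 mL.min-1.g-1 in this assay, at which 3 of the 4 values shown sit.

The compounds shown leave open whether fluoro in place of hydrogen on an aromatic carbon shifts clearance in this assay at all, and by how much.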